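The source may report more compounds than this note shows. Statements on the series, on what has been measured and on what is new or still open speak of the compounds shown alone.

Measured so far in a functional assay on MDA-MB-231 cells for antagonist activity at C-X-C chemokine receptor type 4 (Homo sapiens), tested at 100 nM; a higher number here means a stronger effect of the compound at the concentration tested, a lower number a weaker effect:
compound 1 `Clc1nc(Cl)nc(NCc2ccc(CNc3nc(Cl)nc(Cl)n3)cc2)n1` gives 82%
compound 2 `Clc1cccc(NCc2ccc(CNc3ncccn3)cc2)n1` gives 100%

Compound 2 stands highest of the two numbers in this assay; its nearest neighbour is compound 1, whose number lies lower by a gap beyond the usual scatter. Going by the values given here, the two measured compounds differ in more than one place, so no single-change step between measured compounds is available, and the size of a one-place step is not yet known.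

Compound 3 `Clc1ccc(NCc2ccc(CNc3ncccn3)cc2)nc1` is still to be measured. It differs from compound 2 by 5-chloropyridin-2-yl in place of 6-chloropyridin-2-yl on an amine nitrogen. With the same atoms joined differently, only a small step is expected in this assay, and it can only hold or go down because compound 2 already gives 100%. Compound 3 is expected to give 88%, within a range of 60% to 100%. The expected step is a number 12 percentage points lower from compound 2 to compound 3 (beyond the scatter), downward but near the edge of the scatter.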

Compound 3, a percentage reported as inhibition, at one concentration (the size of the read-out at that concentration, not a potency): 100%
The estimate for compound 3 lay 12 percentage points below the measured number, and the stated range covers the measured number.
By their numbers in this assay, from the lowest: compound 1; then compounds 2 and 3 (each within the scatter of the next).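

Going by these compounds alone, replacing 6-chloropyridin-2-yl with 5-chloropyridin-2-yl on an amine nitrogen gives the first single-place step: in this assay, the read-out shows no change at the digits printed from compound 2 to compound 3 (within the scatter). This place therefore accepts either chloropyridinyl isomer at the concentration tested, with the same atoms joined differently and no loss visible. Both compounds sit at the top of the read-out, so a single concentration cannot separate them, and a difference in potency could remain hidden; no supporting data explain the outcome.

From the compounds shown here alone, it remains open how a pyridin-2-yl without chlorine, or a plain phenyl ring, would read on this amine nitrogen. Any ranking of compound 2 and compound 3 would need a lower concentration or a full concentration-response curve.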